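Removing the benzyl from the primary alcohol of compound 1

The compounds below may be only part of what the source reports. "The series", "measured", "known", "first", "only" and "open" are said of these compounds alone.

Among the measured compounds shown here, compound 1 `CCOC(=O)C1=C(C)OC2OC(COCc3ccccc3)C(OCc3ccccc3)C(O)C2S1` supplies the only numerical value here: in an assay on CHO cells for displacement of a labelled ligand from Substance-K receptor (Homo sapiens) (on this read-out lower numbers stand for stronger inhibition and higher numbers for weaker inhibition), compound 1 gives 12600 nM. Compound 2 `CCOC(=O)C1=C(C)OC2OC(COCc3ccccc3)C(O)C(OCc3ccccc3)C2[S+]1[O-]` reaches only a limit of this assay, > 10000 nM, which is the limit of > 10000 nM in this assay, at which 1 of the 2 values shown sits. Compound 3 `CCOC(=O)C1=C(C)OC2OC(CO)C(OCc3ccccc3)C(O)C2S1` differs from compound 1 by hydrogen in place of benzyl on an oxygen on a saturated carbon. For the measured compounds named here, no measured step of this kind exists; the expected step of a 1.6-fold higher number from compound 1 to compound 3 (0.20 log units; within the scatter) points toward weaker inhibition in this assay, though no change beyond the scatter would also fit. Compound 3 is expected at 20000 nM, within 6000 nM to 60000 nM, with a fair chance that this assay returns only a limit.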

Compound 3, inhibition constant: > 10000 nM
Compound 3 ended at the assay's limit; the forecaster's own chance of this, stated with the estimate: 55%; the middle value is on the limit's open side.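

Among the compounds shown here, compound 3 gives > 10000 nM in this assay, which is a limit and not a number, so no step from compound 1 to compound 3 can be read. On these data alone, whether hydrogen in place of benzyl changes inhibition, and by how much, stays open.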